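This account rests on a few compounds, and the source may have more. Where it says the series, first, only, none or still open, it means among the compounds named here.

In a functional assay on A549 cells (Homo sapiens) for inhibition, read by sulforhodamine B assay (on this read-out lower numbers stand for stronger inhibition of growth and higher numbers for weaker inhibition of growth), compound 1 `FC(F)(F)Oc1ccc(-c2ccc(-c3ccc(-c4nc5ccccc5[nH]4)cc3)cc2)cc1` gives 38000 nM, while compound 2 `Oc1cccc2[nH]c(-c3ccc(-c4ccc(-c5ccc(C(F)(F)F)cc5)cc4)cc3)nc12` gives 3610 nM, the lower of the two numbers by a gap beyond the scatter. Compound 3 `Oc1cccc2[nH]c(-c3ccc(-c4ccc(-c5ccc(OC(F)(F)F)cc5)cc4)cc3)nc12` differs from compound 2 by trifluoromethoxy in place of trifluoromethyl on an aromatic carbon, para to a large group (trifluoromethoxy in place of trifluoromethyl on an aromatic carbon). Within the data shown here, no measured pair shows this change, so the expectation rests on the structural change alone. The step of a 1.1-fold higher number from compound 2 to compound 3 (0.04 log units; within the scatter) is expected to stay within the scatter, in neither direction. The estimated value for compound 3 is 4000 nM, with an expected range from 1500 nM to 12000 nM.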

Compound 3, concentration for 50% growth inhibition: 190 nM
Compound 3: middle estimate off by 21-fold (1.32 log units), on the high side, and the stated range ends above it.
By their numbers in this assay, from the lowest: compound 3; then compound 2; then compound 1.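

Swapping trifluoromethyl for trifluoromethoxy on this aromatic carbon, para to a large group, is not a neutral exchange in this assay: the change gives a 19-fold lower number from compound 2 to compound 3 (1.28 log units; beyond the scatter). With trifluoromethoxy held constant, hydroxy in place of hydrogen on an aromatic carbon gives a 200-fold lower number from compound 1 to compound 3 (2.30 log units; beyond the scatter), separating two changes that the comparison of compound 1 with compound 2 could not. Nothing available bears on the cause of either step. The compounds shown leave open whether a methoxy group could stand in for the hydroxy, and how an amine or a longer fluorinated chain would fare in place of trifluoromethoxy.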